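Piperidine in place of dimethylamino on the pyridine-bearing series

This account rests on a few compounds, and the source may have more. Where it says the series, first, only, none or still open, it means among the compounds named here.

Three analogues of the shared core have numbers in a functional assay on CHO-K1 cells for antagonist activity at transient receptor potential cation channel subfamily V member 1 (Homo sapiens), read by FLIPR; on this read-out lower numbers stand for stronger inhibition and higher numbers for weaker inhibition. Compound 1 `CC(C(=O)NCc1ccc(C(F)(F)F)nc1N(C)C)c1ccc(NS(C)(=O)=O)c(F)c1` gives 19.1 nM in this assay and stands second highest of the three. Compound 2 `C[C@H](C(=O)NCc1ccc(C(F)(F)F)nc1N1CC[C@@H](N(C)C)C1)c1ccc(NS(C)(=O)=O)c(F)c1` gives 101 nM, the highest number of the set, and compound 3 `C[C@@H](C(=O)NCc1ccc(C(F)(F)F)nc1N1CCC(c2ccccc2)CC1)c1ccc(NS(C)(=O)=O)c(F)c1` gives 7.5 nM, the lowest; compound 1 therefore sits between a ring-bearing amine that weakens and one that strengthens inhibition.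

Compound 4 `CC(=O)OC1CCN(c2nc(C(F)(F)F)ccc2CNC(=O)C(C)c2ccc(NS(C)(=O)=O)c(F)c2)CC1` is not yet measured. It differs from compound 1 in one place: 4-acetoxypiperidin-1-yl in place of dimethylamino on an aromatic carbon. The change is of the same kind as those leading to compound 2 and compound 3, a cyclic amine in place of the open dimethylamino, and those two move in opposite directions, so the two measured values give no single direction for such a change.

Within the data shown here, with no step between measured compounds to lean on, no change beyond the scatter is expected for compound 4, and the step of a 1.0-fold higher number from compound 1 to compound 4 (0.02 log units; within the scatter) is estimated as small in either direction. Compound 4 is expected to give about 20 nM, with a range from 6 nM to 70 nM.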

Compound 4, inhibition constant: 4 nM
Estimate against measurement, compound 4: 5.0-fold (0.70 log units) above; measured number outside the range, below it.
By their numbers in this assay, from the lowest: compounds 4 and 3 (each within the scatter of the next); then compound 1; then compound 2.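

In this assay, the series gains its first readable step at this position, the aromatic carbon next to the ring nitrogen: a 4.8-fold lower number from compound 1 to compound 4 (0.68 log units; beyond the scatter). The position therefore accepts 4-acetoxypiperidin-1-yl, with its 10 heavy atoms against the 3 of dimethylamino, and the number still moves beyond the scatter towards stronger inhibition, a modest step that shows a large cyclic amine carrying an acetoxy group need not weaken inhibition here. Nothing at hand explains this gain.

The compounds shown leave open whether the gain comes from the piperidine ring itself or from the acetoxy group on it, a question that unsubstituted piperidin-1-yl and 4-hydroxypiperidin-1-yl at this place would separate. Among these compounds, how the single stereoisomers of compound 4 compare also stays open.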